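Butoxy in Place of Acetyl on the Aromatic Ring

The source may hold more compounds than are shown below. What is called first, only, known or untested is meant among the compounds shown, and "the series" means these compounds.

Three measured compounds share one core and differ only in the group on a six-membered aromatic ring of carbon only. Compound 1 `O/N=C(/Nc1cccc(Cl)c1)c1ccc2occc2c1` carries chloro, and in an assay on tissue (HeLa cells) for inhibition of Indoleamine 2,3-dioxygenase 1 (Homo sapiens), read by spectrophotometry (a lower number here means a stronger inhibitor, a higher number a weaker inhibitor), compound 1 gives 1500 nM. Compound 2 `O/N=C(/Nc1cccc(Br)c1)c1ccc2occc2c1` carries bromo, and in this assay compound 2 gives 1100 nM; the step of a 1.4-fold lower number from compound 1 to compound 2 (0.13 log units; within the scatter) lies within the scatter. Compound 3 `CC(=O)c1cccc(N/C(=N/O)c2ccc3occc3c2)c1` carries acetyl. In this assay compound 3 gives only a limit of the assay, > 30000 nM, as recorded in the limit of > 30000 nM in this assay, at which 1 of the 3 values shown sits. Compound 3 thus stands apart from the other two, with the step of an at least 20-fold higher number from compound 1 to compound 3 (1.30 log units; beyond the scatter) and the step of an at least 27-fold higher number from compound 2 to compound 3 (1.43 log units; beyond the scatter) both large and beyond the scatter.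

Compound 4 `CCCCOc1cccc(N/C(=N/O)c2ccc3occc3c2)c1` differs from compound 3 by butoxy in place of acetyl on an aromatic carbon. The measured steps that bear on this change are the two into compound 3, in which acetyl in place of chloro or bromo raised the number sharply. The change to butoxy removes the acetyl, but butoxy is neither chloro nor bromo, so the data do not show whether the number falls back fully to the level of compound 1 and compound 2. A lower number is nonetheless the expected direction. In this assay compound 4 is expected to give 4000 nM, with a range from 1000 nM to 30000 nM. That estimate means an expected step of an at least 7.5-fold lower number from compound 3 to compound 4 (0.87 log units; beyond the scatter).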

Compound 4, half-maximal inhibitory concentration: > 30000 nM
Compound 4 ended at the assay's limit; the forecaster's own chance of this, stated with the estimate: 25%; middle value at least 7.5-fold (0.87 log units) away from the limit.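

Butoxy at this position on the aromatic ring fares no better than acetyl in this assay when set against the two halogen compounds, with an at least 27-fold higher number from compound 2 to compound 4 (1.43 log units; beyond the scatter) and an at least 20-fold higher number from compound 1 to compound 4 (1.30 log units; beyond the scatter). The earlier compounds tied the large loss to acetyl alone, whereas compound 4 shows that a group without acetyl's carbonyl, and with a longer chain, also falls far from chloro and bromo, so among these compounds the loss is not peculiar to acetyl. Compound 3 and compound 4 both stand at a limit of the assay rather than at a number, so the step between them cannot be read and no order can be given for acetyl and butoxy: the limit of > 30000 nM in this assay, at which 2 of the 4 values shown sit.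

The compounds shown leave open whether methoxy, a shorter chain on the same oxygen, or a small group such as methyl or fluoro, would keep the number near that of compound 1 and compound 2. They also leave open whether an amine or a carboxylic acid in this place would side with chloro and bromo or with acetyl and butoxy.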